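A few compounds are considered here, and "the series" means these few. Any claim that something is new, unique, unknown or untested is made for them only; others in the source may bear on it.

Compound 1 `O=C(NCCCCc1ccccc1)c1cccc(C2SCC(=O)N2c2cccc(-c3c[nH]nn3)c2)c1`: 110 nM
Compound 2 `COc1ccccc1N1C(=O)CSC1c1cccc(C(=O)NCCCCc2ccc(Cl)cc2)c1`: 78.6 nM
Compound 3 `COc1cccc(OC)c1N1C(=O)CSC1c1cccc(C(=O)NCCCCc2ccccc2)c1`: > 1000 nM

Of the compounds shown here, three sharing one core have been tested in a functional assay on HOS-TE85 cells (Homo sapiens) for inhibition, read by CCK-8 assay, with a stated time of 72 h; a higher number here means a weaker inhibitor, a lower number a stronger inhibitor. Compound 1 gives 110 nM and compound 2 gives 78.6 nM, and these two values lie within the scatter of each other. For compound 3 only a limit is known: > 1000 nM, which is the limit of > 1000 nM in this assay, at which 1 of the 3 values shown sits. Among the measured compounds shown here, the one measured step that touches compound 3 is an at least 9.0-fold higher number from compound 1 to compound 3 (0.95 log units; beyond the scatter), in which a 2,6-dimethoxyphenyl group took the place of the larger group present in compound 1, and potency fell.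

Compound 4 `O=C(NCCCCc1ccccc1)c1cccc(C2SCC(=O)N2c2nccs2)c1` has not yet been measured. It differs from compound 3 in one place: 1,3-thiazol-2-yl in place of 2,6-dimethoxyphenyl on an amide-type nitrogen in a ring. For the measured compounds named here, no measured pair shows a 1,3-thiazol-2-yl group at this position, so the expectation rests on the loss that accompanied the entry of the 2,6-dimethoxyphenyl group. Removing that group is expected to recover part of the activity, and compound 4 is therefore estimated at 350 nM, within a range of 80 nM to 2000 nM. That estimate corresponds to an expected step of an at least 2.8-fold lower number from compound 3 to compound 4 (0.45 log units; beyond the scatter).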

Compound 4, half-maximal inhibitory concentration: > 1000 nM
Compound 4 gave a limit, no number; the forecaster's own chance of this, stated with the estimate: 25%; at least 2.8-fold (0.45 log units) between middle value and limit.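

In this assay, putting 1,3-thiazol-2-yl on the amide-type nitrogen in place of the larger group of compound 1 gives an at least 9.0-fold higher number from compound 1 to compound 4 (0.95 log units; beyond the scatter). The loss at this position is therefore not tied to 2,6-dimethoxyphenyl alone, since a much smaller ring also fails to bring a reading under the limit. Compound 3 and compound 4 both sit at a limit, so the step between them cannot be read and neither group can be ranked against the other: the limit of > 1000 nM in this assay, at which 2 of the 4 values shown sit.

As far as these compounds go, it remains open how much weaker either compound really is. From the compounds shown here alone, it is also open whether a plain phenyl, or a phenyl carrying a carboxylic acid or an amine, would keep the activity of compound 1 at this position.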